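Moving the ring nitrogen on a topoisomerase inhibitor scaffold

The source may report more compounds than this note shows. Statements on the series, on what has been measured and on what is new or still open speak of the compounds shown alone.

Measured compounds:
compound 1 `Oc1cccc(-c2cc(-c3ccccc3)nc(-c3ccsc3)c2)c1`: 6.9%
compound 2 `Oc1cccc(-c2cc(-c3ccccc3)nc(-c3cccnc3)c2)c1`: 8.1%

In an assay on isolated protein for inhibition of DNA topoisomerase 1 (Homo sapiens), with a stated time of 30 min, tested at 100 uM (a lower number here means a weaker effect, a higher number a stronger effect of the compound at the concentration tested), compound 1 gives 6.9% and compound 2 gives 8.1%. Within the data shown here, the two numbers cannot be told apart: the single measured step, a number 1.2 percentage points higher from compound 1 to compound 2 (within the scatter), changed thiophen-3-yl to pyridin-3-yl at the same place on the shared core and left the read-out within the scatter.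

Compound 3 `Oc1cccc(-c2cc(-c3ccccc3)nc(-c3ccncc3)c2)c1` is the next compound. Its difference from compound 2 is pyridin-4-yl in place of pyridin-3-yl on an aromatic carbon. Among the measured compounds shown here, the only measured step that bears on it is the one from compound 1 to compound 2, which exchanged one small aromatic ring for another at this very position without a change beyond the scatter. On that basis the expected step of a number 0.6 percentage points lower from compound 2 to compound 3 (within the scatter) is small and not beyond the scatter. Compound 3 is therefore expected to give 7.5%, with a range from 0% to 20%.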

Compound 3, a percentage reported as inhibition, at one concentration (the size of the read-out at that concentration, not a potency): 60.8%
Compound 3: the middle estimate sits 53.3 percentage points below what was measured; the whole stated range lies below it.
By their numbers in this assay, from the lowest: compounds 1 and 2 (each within the scatter of the next); then compound 3.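

In this assay, this place on the shared core proves sensitive to a very small edit: the group keeps the same atoms and the same counts, yet going from pyridin-3-yl to pyridin-4-yl comes with a number 52.7 percentage points higher from compound 2 to compound 3 (beyond the scatter). The exchange of thiophen-3-yl for pyridin-4-yl gives a step of similar size, a number 53.9 percentage points higher from compound 1 to compound 3 (beyond the scatter), so among these three compounds having a pyridine ring here is not enough on its own, and only the pyridin-4-yl compound stands out. Nothing measured here explains why this group differs from the other two.

Still open, on these data alone, is whether pyridin-2-yl, plain phenyl or a 4-aminophenyl group at this place would read like pyridin-4-yl or like pyridin-3-yl. Also open, as far as these compounds go, is how strong the effect of compound 3 would be at other concentrations, as the read-out gives only the size of its effect at the one concentration tested.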